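The source may hold more compounds than are shown below. What is called first, only, known or untested is meant among the compounds shown, and "the series" means these compounds.

In a functional assay on HUVEC cells (Homo sapiens) for inhibition, read by ELISA and BrdU incorporation (on this read-out higher numbers stand for weaker inhibition and lower numbers for stronger inhibition), three compounds with a shared core have been measured so far. Compound 1 `O=C(Nc1cccc2cccnc12)c1ccccc1` gives 72.4 nM, compound 2 `Cc1cccc(C(=O)Nc2cccc3cccnc23)c1O` gives 26.3 nM, and compound 3 `O=C(Nc1cccc2cccnc12)c1cc(Br)cnc1O` gives 12.9 nM. That last number is the lowest of the three, and both others lie above it by more than the usual scatter. Compound 4 `Cc1cnc(O)c(C(=O)Nc2cccc3cccnc23)c1` differs from compound 3 in one place: methyl in place of bromo on an aromatic carbon, with methyl in place of bromo on an aromatic carbon. Within the data shown here, no measured pair shows this swap directly, so the expectation is only a rough one. Compound 2 also carries a methyl, and its number is higher than that of compound 3. In this assay the expected change is a small move towards weaker inhibition, near the edge of the scatter, which is estimated as a 1.7-fold higher number from compound 3 to compound 4 (0.23 log units; within the scatter). Compound 4 is expected at 22 nM, with an estimated range from 9 nM to 55 nM.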

Compound 4, half-maximal inhibitory concentration: 13.6 nM
Compound 4: middle estimate off by 1.6-fold (0.21 log units), on the high side, and the stated range covers the measured number.
By their numbers in this assay, from the lowest: compounds 3, 4 and 2 (each within the scatter of the next, the first and the last beyond it); then compound 1.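

Methyl in place of bromo on this aromatic carbon, para to a hydroxy group, gives a 1.1-fold higher number from compound 3 to compound 4 (0.02 log units; within the scatter) in this assay. Among these compounds, this is the first direct reading of this position, and at it the assay does not tell the two groups apart. Nothing available explains why they read alike.

As far as these compounds go, whether the same holds for an amine, a methoxy group or a carboxylic acid on this carbon stays open. So does what a hydrogen alone there would give, with neither methyl nor bromo.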